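This account rests on a few compounds, and the source may have more. Where it says the series, first, only, none or still open, it means among the compounds named here.

Compound 1 `Fc1cccc(F)c1C#Cc1cnc(Cl)c2ccccc12`: 48.1% in a functional assay on LS174T cells (Homo sapiens) for inhibition, with a stated time of 4 days, tested at 1 uM; a higher number here means a stronger effect of the compound at the concentration tested, a lower number a weaker effect
Compound 2 `CN(C)c1ncc(C#Cc2c(F)cccc2F)c2ccccc12`: 99.5% in this assay

Compound 2 stands highest of the two measured compounds; its nearest neighbour is compound 1, and the step of a number 51.4 percentage points higher from compound 1 to compound 2 (beyond the scatter) is large and beyond the scatter. The unmeasured compound 3 `CNc1ncc(C#Cc2c(F)cccc2F)c2ccccc12` differs from compound 2 by hydrogen in place of methyl on a nitrogen on an aromatic ring. Within the data shown here, only one measured step exists, and it concerns a different change, dimethylamino in place of chloro, so it bears on the present change only indirectly: it shows that a nitrogen substituent on the core of compound 1 gives a high reading, but says nothing about removing one methyl from that nitrogen. Compound 2 also sits close to the top of the scale, leaving little room upward. The analyst therefore expects compound 3 to keep most of the effect, with an estimated step of a number 11.5 percentage points lower from compound 2 to compound 3 (beyond the scatter). Compound 3 is estimated at 88%, in a range from 60% to 100%.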

Compound 3, a percentage reported as inhibition, at one concentration (the size of the read-out at that concentration, not a potency): 99.8%
Compound 3: the middle estimate sits 11.8 percentage points below what was measured; the range from low to high includes it.
By their numbers in this assay, from the lowest: compound 1; then compounds 2 and 3 (each within the scatter of the next).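

In this assay, hydrogen in place of methyl on a nitrogen on an aromatic ring gives a step of a number 0.3 percentage points higher from compound 2 to compound 3 (within the scatter), so the second methyl on this nitrogen is not needed for the reading at this concentration, although both readings lie near the top of the scale. Exchanging the chloro group for methylamino gives a number 51.7 percentage points higher from compound 1 to compound 3 (beyond the scatter), which shows that the large step first seen with dimethylamino does not depend on having two methyl groups on the nitrogen. Nothing available gives a reason for either step.

The compounds shown leave open whether the unsubstituted amine or a longer chain such as ethyl on this nitrogen would give a similar reading. Going by these compounds, a reading at one concentration is not a potency, so how compound 2 and compound 3 compare at lower concentrations also stays open.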